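Working notes: from compound 3 to compound 4

A few compounds are considered here, and "the series" means these few. Any claim that something is new, unique, unknown or untested is made for them only; others in the source may bear on it.

Measured so far in an ADME assay on MDBK cells (Bos taurus) for cytotoxicity (on this read-out lower numbers stand for higher toxicity in this test and higher numbers for lower toxicity in this test), and all given as limits
- compound 1 `Fc1cccc(F)c1Cn1cccc2nc(-c3c(F)cccc3F)nc1-2` with > 100000 nM as its limit
- compound 2 `Cc1ccn(Cc2c(F)cccc2F)c2nc(-c3c(F)cccc3F)nc1-2` with > 100000 nM as its limit
- compound 3 `COc1ccccc1Cn1ccc2nc(-c3ccccc3)nc-2c1` with > 100000 nM as its limit

Compound 3 stands at > 100000 nM and this is a limit of the assay, not a number. It has no readable position relative to compound 1 or compound 2, since the whole set shows the limit of > 100000 nM in this assay, at which 3 of the 3 values shown sit, and nothing more.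

Compound 4 `Fc1ccc(Cn2ccc3nc(-c4ccccc4)nc-3c2)cc1` is the next to be read. The change from compound 3 is 4-fluorophenyl in place of 2-methoxyphenyl on a saturated chain carbon bound to an aromatic nitrogen and in words it is 4-fluorophenyl in place of 2-methoxyphenyl on a saturated chain carbon bound to an aromatic nitrogen.

For the measured compounds named here, only one measured step is available, a step that the two limits leave unreadable from compound 1 to compound 2 and it concerns a different change, so it offers no size to carry over. With no readable step to go on, no shift in either direction is expected in this assay beyond the scatter. The expected outcome is a number no higher from compound 3 to compound 4 (the limit leaves the size open) in the estimate, and a further limit is the most likely report. For compound 4 the estimated value is 100000 nM with an expected range from 30000 nM to 300000 nM for the measurement.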

Compound 4, half-maximal cytotoxic concentration: > 100000 nM
Compound 4: only a limit was reported; the forecaster's own chance of this, stated with the estimate: 80%; the middle value lies on the limit itself.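

The change from compound 3 to compound 4 gives no readable step in this assay, as the result is again only a limit and the set sits at it throughout: the limit of > 100000 nM in this assay, at which 4 of the 4 values shown sit.

The compounds shown leave open how far any of them lies from that limit, and whether any change to the shared core would give a readable value.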